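Adding a second tert-butyl group to a longer-linked resveratrol analogue

This account rests on a few compounds, and the source may have more. Where it says the series, first, only, none or still open, it means among the compounds named here.

Compound 1 `CC(C)(C)c1cc(/C=C/c2cc(O)cc(O)c2)ccc1O` and compound 2 `CC(C)(C)c1cc(/C=C/c2cc(O)cc(O)c2)cc(C(C)(C)C)c1O` share one core, while compound 3 `CC(C)(C)c1cc(/C=C/C=C/c2cc(O)cc(O)c2)ccc1O` is built on a second core; the difference between the two cores is not broken down here. In a functional assay on HT-22 cells (Mus musculus), read by MTT assay, with a stated time of 24 h (a lower number here means that less compound is needed, a higher number that more compound is needed for the effect), compound 1 gives 484 nM, and in the same setting compound 2 gives 45 nM. The change between them is tert-butyl in place of hydrogen on an aromatic carbon, and it produced an 11-fold lower number from compound 1 to compound 2 (1.03 log units; beyond the scatter). Compound 3 gives 91 nM in this assay, placing it second among the three measured compounds, with compound 2 below it and compound 1 above it, both gaps beyond the scatter.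

Compound 4 `CC(C)(C)c1cc(/C=C/C=C/c2cc(O)cc(O)c2)cc(C(C)(C)C)c1O` differs from compound 3 by tert-butyl in place of hydrogen on an aromatic carbon. The surroundings of the change are the same, word for word, as in the pair of compound 1 and compound 2, so it is the same change. Because an 11-fold lower number from compound 1 to compound 2 (1.03 log units; beyond the scatter) was large, a step of similar direction is expected, namely a 7.6-fold lower number from compound 3 to compound 4 (0.88 log units; beyond the scatter), though the unknown influence of the second core widens the uncertainty. Compound 4 is therefore expected near 12 nM, with a plausible range from 4 nM to 40 nM.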

Compound 4, half-maximal effective concentration: 119 nM
For compound 4 the middle estimate is 9.9-fold (1.00 log units) below the measured one; the whole stated range lies below it.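

In this assay, within the data shown here, placing a tert-butyl group on the aromatic carbon ortho to a hydroxy group gave a 1.3-fold higher number from compound 3 to compound 4 (0.12 log units; within the scatter), so on the core of compound 3 this change produced no step that can be told from the scatter. Set beside the step on the core shared by compound 1 and compound 2, the same change did not carry over from one core to the other: the same change on two cores in this assay, an 11-fold lower number (1.03 log units; beyond the scatter) from compound 1 to compound 2 and a 1.3-fold higher number (0.12 log units; within the scatter) from compound 3 to compound 4, 14-fold (1.15 log units) apart, beyond the scatter of two such steps. This shows that the step differs between these two pairs, but it does not show which feature of the cores accounts for the difference, nor what the change would do on any further core.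

The compounds shown leave open whether a methyl or isopropyl group in the same place would give a step that differs between the two cores in the same way. They also leave open whether a methoxy group in place of the neighbouring hydroxy group would alter either step.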